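The source may hold more compounds than are shown below. What is called first, only, known or untested is meant among the compounds shown, and "the series" means these compounds.

Compound 1, `CC(C)N1CCC(Oc2ccc(C(=O)Nc3ccc(NC(=O)Nc4cc(C(C)(C)C)on4)cc3)nc2)CC1`, was studied in an in vivo ADME assay on the whole organism (plasma, strain Sprague-Dawley) for pharmacokinetics, with Rattus norvegicus as the target, read by LC-MS; a lower number here means slower removal, a higher number faster removal of the compound. In this assay compound 1 gives 16 mL/min/kg. Two other compounds share its core. Among the compounds with values here, compound 2, `Cc1ccnc(C(=O)Nc2ccc(NC(=O)Nc3cc(C(C)(C)C)on3)cc2)c1`, gives 37.9 mL/min/kg in this assay, a value that sits beyond the scatter above that of compound 1, so compound 1 stands with the lowest of the two numbers known. Compound 3, `CCN1CCC(Oc2ccnc(C(=O)Nc3ccc(NC(=O)Nc4cc(C(C)(C)C)on4)cc3)c2)CC1`, was also made, but in this assay compound 3 gives "not determined" (no result reported), so it adds nothing to the comparison. No pair among these compounds differs in just one place, so no single-change step can be read from the measured compounds.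

Compound 4, `CC(C)(C)c1cc(NC(=O)Nc2ccc(NC(=O)c3ccc(OC4CCN(C(C)(C)C)CC4)cn3)cc2)no1`, is the next compound to be measured in this assay. It differs from compound 1 by methyl in place of hydrogen on a saturated chain carbon bound to an amine nitrogen in a ring and two saturated chain carbons, the same change read one bond further out as isopropyl to tert-butyl. Within the data shown here, no measured step of this kind is known here, so the size of the change cannot be taken from the data. The expectation is that compound 4 moves little, with a step of a 1.1-fold lower number from compound 1 to compound 4 (0.06 log units; within the scatter) that stays within the scatter or leans only slightly toward a lower number. The estimate for compound 4 is 14 mL/min/kg, with a range from 7 mL/min/kg to 28 mL/min/kg.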

Compound 4, clearance: 15 mL/min/kg
Beside the measured number, compound 4's estimate is 1.1-fold (0.03 log units) below it; the measured number falls inside the stated range.
By their numbers in this assay, from the lowest: compounds 4 and 1 (each within the scatter of the next); then compound 2.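

Within the data shown here, this is the first change in the set that can be read on its own. In this assay, placing methyl in place of hydrogen, which turns isopropyl into tert-butyl, gives a 1.1-fold lower number from compound 1 to compound 4 (0.03 log units; within the scatter) and so leaves compound 1 and compound 4 indistinguishable within the usual scatter of repeated measurements. At this position on a saturated chain carbon bound to an amine nitrogen in a ring, one added methyl therefore produces no readable shift in how fast the compound is removed from the rat, and nothing measured here explains why.

This single step says nothing about what a different kind of group at the same place would do, such as a cyclopropyl ring, a longer chain like n-butyl, or a chain ending in a carboxylic acid. Compound 2 differs from compound 1 and compound 4 in more than one place, so the compounds shown also leave open which part of the structure accounts for the gap between its number and theirs.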